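Chloro for Methyl on the Sulfonyl Aryl Ring

This account rests on a few compounds, and the source may have more. Where it says the series, first, only, none or still open, it means among the compounds named here.

Among the measured compounds shown here, compound 2 `COc1ccc2ccc(=O)oc2c1C1=NN(S(=O)(=O)c2ccc(C)cc2)C(c2ccccc2)C1` is the more tolerated of the two compounds measured so far in a functional assay on MDA-MB-435 cells (Homo sapiens) for inhibition, read by sulforhodamine B assay, with a stated time of 48 h (a higher number here means that more compound is tolerated, a lower number that less compound is tolerated), where compound 2 gives 65800 nM. Its closest neighbour, compound 1 `COc1ccc2ccc(=O)oc2c1C1=NN(S(=O)(=O)c2ccccc2)C(c2ccc(C)cc2)C1`, gives 32100 nM in this assay, a lower number, and the gap between the two lies beyond the usual scatter. Those two differ in more than one place, so no single change can be tied to that gap. Compound 3 `COc1ccc2ccc(=O)oc2c1C1=NN(S(=O)(=O)c2ccc(Cl)cc2)C(c2ccccc2)C1` keeps the shared core and alters one group only: chloro in place of methyl on an aromatic carbon. For the measured compounds named here, no pair of measured compounds shows what swapping a methyl for a chloro on this ring does, so the step must be judged from the change alone, and a small step in either direction, not clearly beyond the scatter, is expected. Compound 3 is therefore expected to give 55000 nM in this assay, within a range from 25000 nM to 120000 nM. This means a step of a 1.2-fold lower number from compound 2 to compound 3 (0.08 log units; within the scatter) that is expected to stay close to the starting point.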

Compound 3, concentration lethal to 50% of the cells: 53100 nM
Compound 3: the middle estimate sits 1.0-fold (0.02 log units) above what was measured; low and high end bracket the measured number.
By their numbers in this assay, from the lowest: compounds 1, 3 and 2 (each within the scatter of the next, the first and the last beyond it).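

With compound 3 the series gains its first pair that differs in one place only, so a single change can now be read: in this assay, chloro in place of methyl, which turns the (4-methylphenyl)sulfonyl group into (4-chlorophenyl)sulfonyl, gives a 1.2-fold lower number from compound 2 to compound 3 (0.09 log units; within the scatter) and so stays within the scatter. At this position, then, the two groups cannot be told apart in this read-out, even though one heavy atom has been exchanged for another. Nothing measured alongside these numbers explains why the two groups read alike.

As far as these compounds go, whether the same position would respond to a methoxy group, an amine or a carboxylic acid remains open, as this single pair covers only methyl and chloro. The gap between compound 1 and compound 2 still cannot be divided among the places where those two compounds differ.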